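The source may hold more compounds than are shown below. What is called first, only, known or untested is meant among the compounds shown, and "the series" means these compounds.

Measured so far:
compound 1 `COc1cc(N)c(Cl)cc1NC(=O)C1CCN(Cc2cccc(C)c2)CC1` gives 2.4 mg/kg
compound 2 `CCOc1ccc(CN2CCC(C(=O)Nc3cc(Cl)c(N)cc3OC)CC2)cc1` gives 6.3 mg/kg

Both numbers come from a functional assay on the whole organism for antagonist activity, with Mus musculus as the target; on this read-out lower numbers stand for an effect already at smaller amounts and higher numbers for an effect only at larger amounts of compound. Within the data shown here, compound 2 stands at the higher of the two numbers; the only other compound, compound 1, lies at a lower number, and the step from compound 1 to compound 2 was a 2.6-fold higher number from compound 1 to compound 2 (0.42 log units; beyond the scatter).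

Compound 3 `COc1cc(N)c(Cl)cc1NC(=O)C1CCN(CC2CCCCCC2)CC1` has not yet been measured. It differs from compound 2 in one place: cycloheptyl in place of 4-ethoxyphenyl on a saturated chain carbon bound to an amine nitrogen in a ring. Among the measured compounds shown here, the one measured step that bears on this place, from compound 1 to compound 2, was a 2.6-fold higher number from compound 1 to compound 2 (0.42 log units; beyond the scatter); it shows that exchanging the group on this carbon moves this assay by only a modest amount. An exchange of an aromatic ring for a saturated ring is not covered by any measured pair, so the direction is open. The expectation is therefore no step beyond the scatter, or at most a modest one either way, shown as a 1.3-fold lower number from compound 2 to compound 3 (0.10 log units; within the scatter). Compound 3 is estimated at 5 mg/kg, in a range from 1.5 mg/kg to 18 mg/kg.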

Compound 3, dose for half-maximal effect: > 10 mg/kg
Compound 3: no number, only a limit; the forecaster's own chance of this, stated with the estimate: 10%; middle value at least 2.0-fold (0.30 log units) from the limit.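

Compound 3 gives no number, only a limit, in this assay: the limit of > 10 mg/kg in this assay, at which 1 of the 3 values shown sits. Among these compounds, the earlier pair held only aromatic rings on this carbon, and this is the first reading with a saturated ring there: the exchange of 3-methylphenyl for cycloheptyl gives an at least 4.1-fold higher number from compound 1 to compound 3 (0.61 log units; beyond the scatter). So on this carbon, the seven-membered saturated ring does not keep the effect at the smaller doses seen with 3-methylphenyl, while the exchange of 4-ethoxyphenyl for cycloheptyl gives an at least 1.5-fold higher number from compound 2 to compound 3 (0.20 log units; that floor lies within the scatter), which does not by itself separate those two groups.

As far as these compounds go, how far the true value of compound 3 lies past its limit remains unknown. Cycloheptyl differs from both aromatic groups in ring size as well as in being saturated, so whether cyclohexyl or a pyridyl ring would behave like cycloheptyl or like 3-methylphenyl stays open.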